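Methoxy in Place of Methyl Sulfoxide on a Benzylamide

The compounds below may be only part of what the source reports. "The series", "measured", "known", "first", "only" and "open" are said of these compounds alone.

Measured in an assay on HeLa cells with Bile acid receptor (Homo sapiens) as the target, read by a luciferase reporter, with a stated time of 24 h (a lower number here means that less compound is needed, a higher number that more compound is needed for the effect), so far:
- compound 1, `O=C(O)c1ccc(CNC(=O)c2cccc(-c3ccccc3)c2)cc1`: 670 nM
- compound 2, `C[S+]([O-])c1ccc(CNC(=O)c2ccc(C(C)(C)C)cc2)cc1`: 1300 nM

Compound 2 stands alongside compound 1 on these two numbers; the gap between them lies within the usual scatter, so no order can be read from them. Compound 3, `COc1ccc(CNC(=O)c2ccc(C(C)(C)C)cc2)cc1`, is not yet measured. It differs from compound 2 in one place: a group of 2 heavy atoms (1 carbon, 1 oxygen; no ring) in place of a group of 3 heavy atoms (1 carbon, 1 oxygen, 1 sulfur; no ring), on an aromatic carbon. Going by the values given here, no step between two measured compounds matches this change, so there is no direct precedent in this set. Given that the two measured compounds sit so close together, the account expects compound 3 to stay near compound 2 in this assay, with a step of a 1.3-fold lower number from compound 2 to compound 3 (0.11 log units; within the scatter) that is estimated to lie within or only slightly beyond the scatter. The estimated value for compound 3 is 1000 nM, with a range from 350 nM to 3000 nM.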

Compound 3, half-maximal effective concentration: 150 nM
Compound 3: the middle estimate sits 6.7-fold (0.82 log units) above what was measured; the whole stated range lies above it.
By their numbers in this assay, from the lowest: compound 3; then compounds 1 and 2 (each within the scatter of the next).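

In this assay, the group on an aromatic carbon para to a large group proves to matter: methoxy in place of the sulfur-bearing group gives an 8.7-fold lower number from compound 2 to compound 3 (0.94 log units; beyond the scatter). Going by these compounds alone, this is the first step in the set between compounds that differ in one place, and it shows that the number responds to this exchange even though the two groups have the same counts of hydrogen-bond donors and acceptors and neither carries a net charge. No measurement shown here accounts for the size of this step.

On these data alone, whether an amine, a hydroxy group, or a longer chain such as ethoxy at this position would give a lower or a higher number remains open. So does whether the same exchange would give a step of similar size with a different large group on the other ring.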